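A few compounds are considered here, and "the series" means these few. Any claim that something is new, unique, unknown or untested is made for them only; others in the source may bear on it.

Measured so far in a functional assay on the whole organism for antagonist activity, with Mus musculus as the target; on this read-out lower numbers stand for an effect already at smaller amounts and higher numbers for an effect only at larger amounts of compound:
compound 1, `COc1cc(N)c(Cl)cc1NC(=O)C1CCN(CC2CC2)CC1`, > 10 mg/kg
compound 2, `COc1cc(N)c(Cl)cc1NC(=O)C1CCN(CC2CCCCCC2)CC1`, > 10 mg/kg
Not yet measured: compound 3, `CCC(CC)CN1CCC(C(=O)Nc2cc(Cl)c(N)cc2OC)CC1`

Compound 2 stands at a limit of the assay and not at a number: in this assay compound 2 gives > 10 mg/kg. Compound 1 likewise gives > 10 mg/kg in this assay, again a limit. Among the compounds with values here, the one step between measured compounds, a step that the two limits leave unreadable from compound 1 to compound 2, is therefore not readable; both of its ends rest on (the limit of > 10 mg/kg in this assay, at which 2 of the 2 values shown sit).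

The change to compound 3 is pentan-3-yl in place of cycloheptyl on a saturated chain carbon bound to an amine nitrogen in a ring. Within the data shown here, the change from compound 1 to compound 2 also altered the group on this saturated chain carbon, but there a ring stayed in place; no measured step has an open chain entering at this position. With both measured values at the limit, the series gives no readable step from which to size the step in this assay, and no direction beyond the scatter can be expected.

Compound 3 is therefore expected to sit near the same limit, at about 20 mg/kg, with a range from 8 mg/kg to 60 mg/kg. The step is estimated as a step that the limit leaves unreadable from compound 2 to compound 3, within the scatter.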

Compound 3, dose for half-maximal effect: > 10 mg/kg
Compound 3 ended at the assay's limit; the forecaster's own chance of this, stated with the estimate: 75%; the middle value lies beyond the limit too.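

In this assay compound 3 gives > 10 mg/kg, which is a limit. No step among compound 1, compound 2 and compound 3 can be read, as all three stand at the same limit: the limit of > 10 mg/kg in this assay, at which 3 of the 3 values shown sit.

The compounds shown leave open whether cyclopropyl, cycloheptyl and pentan-3-yl differ at all at this place in this assay.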